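From 4-methoxyphenyl to naphthalen-1-yl on the sulfonyl sulfur

A few compounds are considered here, and "the series" means these few. Any claim that something is new, unique, unknown or untested is made for them only; others in the source may bear on it.

In a functional assay on LOX IMVI cells (Homo sapiens) for cytotoxicity, read by MTT assay, with a stated time of 24 h (a lower number here means a stronger inhibitor, a higher number a weaker inhibitor), compound 1 `O=S(=O)(NCCCNc1nccc(-c2[nH]c(-c3ccccc3)nc2-c2ccc(F)c(O)c2)n1)c1ccc(Cl)cc1` gives 14200 nM, compound 2 `O=S(=O)(NCCCNc1nccc(-c2[nH]c(-c3ccccc3)nc2-c2ccc(F)c(O)c2)n1)c1ccc(Br)cc1` gives 5660 nM and compound 3 `COc1ccc(S(=O)(=O)NCCCNc2nccc(-c3[nH]c(-c4ccccc4)nc3-c3ccc(F)c(O)c3)n2)cc1` gives 13900 nM. Compound 3 thus stands with compound 1 at the high end of these three numbers. The data show a 1.0-fold lower number from compound 1 to compound 3 (0.01 log units; within the scatter) and a 2.5-fold higher number from compound 2 to compound 3 (0.39 log units; beyond the scatter).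

Compound 4 `O=S(=O)(NCCCNc1nccc(-c2[nH]c(-c3ccccc3)nc2-c2ccc(F)c(O)c2)n1)c1cccc2ccccc12` has naphthalen-1-yl in place of 4-methoxyphenyl on a sulfonyl sulfur. Within the data shown here, no measured compound carries this group, so the evidence is indirect. The other exchanges on this aromatic group reach only a 2.5-fold lower number from compound 1 to compound 2 (0.40 log units; beyond the scatter), a modest size. No change beyond the scatter is therefore expected in this assay, and the expected step is a 1.5-fold lower number from compound 3 to compound 4 (0.19 log units; within the scatter). Compound 4 is estimated at 9000 nM, within an expected range of 3500 nM to 22000 nM.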

Compound 4, half-maximal inhibitory concentration: 3710 nM
Beside the measured number, compound 4's estimate is 2.4-fold (0.38 log units) above it, within the range that was stated.
By their numbers in this assay, from the lowest: compounds 4 and 2 (each within the scatter of the next); then compounds 3 and 1 (each within the scatter of the next).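

Within this assay, replacing the substituted phenyl ring with naphthalen-1-yl moves the number beyond the scatter in two comparisons: a 3.7-fold lower number from compound 3 to compound 4 (0.57 log units; beyond the scatter) and a 3.8-fold lower number from compound 1 to compound 4 (0.58 log units; beyond the scatter). Against 4-bromophenyl the exchange gives a 1.5-fold lower number from compound 2 to compound 4 (0.18 log units; within the scatter), so at this sulfonyl sulfur naphthalen-1-yl matches 4-bromophenyl and does not surpass it. Nothing available here accounts for these steps. Going by these compounds, it remains open what naphthalen-2-yl or a simple methyl group would give on the sulfonyl sulfur. On these data alone, whether a longer chain on the sulfonamide nitrogen would shift the number also stays open.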